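The source may hold more compounds than are shown below. What is called first, only, known or untested is meant among the compounds shown, and "the series" means these compounds.

In a physicochemical assay for solubility, in phosphate buffer, with a stated time of 18 h, at pH 7.4 (on this read-out lower numbers stand for lower solubility and higher numbers for higher solubility), compound 1 `COc1cc2ncnc(-n3nc(-c4ccccn4)nc3N)c2cc1[N+](=O)[O-]` gives 2000 nM. Compound 2 `Nc1nc(-c2ccccn2)nn1-c1ncnc2cc(N3CCNCC3)c([N+](=O)[O-])cc12` gives 4000 nM and compound 3 `COc1cc2ncnc(-n3nc(-c4ccccc4)nc3N)c2cc1OC` gives 1000 nM. Compound 1 lies within the scatter of each of them. Compound 4 `COCCOc1cc2c(-n3nc(-c4ccccn4)nc3N)ncnc2cc1OC` differs from compound 1 by 2-methoxyethoxy in place of nitro on an aromatic carbon, ortho to a methoxy group. Within the data shown here, the only measured step, a 2.0-fold higher number from compound 1 to compound 2 (0.30 log units; within the scatter), concerns a different change, piperazin-1-yl in place of methoxy, and stays within the scatter. Among the measured compounds shown here, no measured step replaces the nitro group. Compound 3 also has no nitro group, though it differs elsewhere too, and its 1000 nM is within the scatter of compound 1. No change beyond the scatter is therefore expected in this assay. The expected step is a 1.3-fold lower number from compound 1 to compound 4 (0.12 log units; within the scatter). For compound 4 the estimated value is 1500 nM, with an expected range of 600 nM to 4000 nM.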

Compound 4, solubility: 8000 nM
For compound 4 the middle estimate is 5.3-fold (0.73 log units) below the measured one; the measured number lies above the stated range.
By their numbers in this assay, from the lowest: compounds 3, 1, 2 and 4 (each within the scatter of the next, the first and the last beyond it).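

Putting 2-methoxyethoxy in place of nitro, ortho to a methoxy group, gives a 4.0-fold higher number from compound 1 to compound 4 (0.60 log units; beyond the scatter) in this assay and is the only step shown that lies beyond the scatter. Among these compounds, it is also the first measured step at this position, which shows that this position can respond to a change of group. Nothing available explains the difference.

The compounds shown leave open whether the ether chain itself matters or the loss of nitro is enough. A shorter ethoxy group or a morpholine at this position would help separate the two.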